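The source may hold more compounds than are shown below. What is called first, only, known or untested is meant among the compounds shown, and "the series" means these compounds.

Values in an ADME assay on MT4 cells (Homo sapiens) for cytotoxicity, read by MTT assay, with a stated time of 5 days (on this read-out higher numbers stand for lower toxicity in this test and lower numbers for higher toxicity in this test), so far:
- Compound 1 `COc1cc2nc(SCC(=O)Nc3ccc(C#N)cc3)nc(Nc3c(C)cc(/C=C/C#N)cc3C)c2cc1OC` gives > 227000 nM as a limit of the assay.
- Compound 2 `COc1cc2nc(SCC(=O)Nc3cccc(Cl)c3)nc(Nc3c(Cl)cc(/C=C/C#N)cc3Cl)c2cc1OC` gives > 208000 nM as a limit of the assay.
- Compound 3 `COc1cc2nc([S+]([O-])CC(=O)Nc3ccc(F)cc3)nc(Nc3c(C)cc(/C=C/C#N)cc3C)c2cc1OC` gives 27400 nM as a measured number.

Compound 3 is the only one of the three with a measured number, and the other two values are limits. Its number lies under both limits, which places it on the more toxic side of what has been seen so far. Compounds 1 and 2 differ from compound 3 in more than one place, so neither gives a clean comparison.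

The next compound is compound 4 `COc1cc2nc([S+]([O-])CC(=O)Nc3ccc([N+](=O)[O-])cc3)nc(Nc3c(C)cc(/C=C/C#N)cc3C)c2cc1OC` and it keeps everything in compound 3 except one group. That change, para to a large group, is nitro in place of fluoro on an aromatic carbon in full.

Among the measured compounds shown here, no step between measured compounds is available to size this change. The expectation therefore rests on compound 3 at 27400 nM as the single anchor. A small move toward lower numbers in this assay is expected, close to the scatter, with a limit value still possible. The expected size is a 1.4-fold lower number from compound 3 to compound 4 (0.14 log units; within the scatter) for this change. For compound 4 the estimated value is 20000 nM with an expected range of 7000 nM to 70000 nM as the working bracket.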

Compound 4, half-maximal cytotoxic concentration: 189000 nM
The estimate for compound 4 lay 9.5-fold (0.98 log units) below the measured number, and the stated range ends below it.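

In this assay, the aryl end of the (4-fluorophenyl)carbamoyl group turns out to be a place where one substitution moves the read-out: nitro in place of fluoro gives a 6.9-fold higher number from compound 3 to compound 4 (0.84 log units; beyond the scatter), toward lower toxicity in this test. Among the compounds shown here, this is the first step between two measured numbers, so the position, para to a large group, can now be sized for at least one change, which the earlier compounds could not do because they differ from compound 3 in more than one place. Nothing shown here gives a measured property of either group that would account for the step, so it stands as an observation only.

As far as these compounds go, it remains open whether the trend continues across other groups at this position, such as an amine or a carboxylic acid, or whether the step is specific to nitro and fluoro. For the compounds shown here, it is equally open whether the same change carries the same size in compounds with an unoxidised sulfur in the linker, since only a single pair is available to size it.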